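The compounds below may be only part of what the source reports. "The series", "measured", "known", "first", "only" and "open" are said of these compounds alone.

Measured so far in a functional assay on the whole organism for agonist activity, with Mus musculus as the target; on this read-out lower numbers stand for an effect already at smaller amounts and higher numbers for an effect only at larger amounts of compound:
Compound 1, `CC(=O)N(C)C(C)C#CCn1ccnc1`, gives 3 mg/kg.
Compound 2, `CC(=O)N(C)C(C)C#CCn1ccnc1C`, gives only a limit, > 100 mg/kg.
Compound 3, `CC(=O)N(C)CC#CCn1ccnc1`, gives 1.4 mg/kg.

Compound 3 differs from compound 1 by hydrogen in place of methyl on a saturated chain carbon bound to an amide-type nitrogen and a triple-bonded carbon, a change that gives a 2.1-fold lower number from compound 1 to compound 3 (0.33 log units; beyond the scatter). Compound 2 differs from compound 1 by methyl in place of hydrogen on an aromatic carbon; this step is an at least 33-fold higher number from compound 1 to compound 2 (1.52 log units; beyond the scatter), and the value of compound 2 sits at the limit of > 100 mg/kg in this assay, at which 1 of the 3 values shown sits. Compound 4, `CC(=O)N(C)CC#CCn1cncc1C`, is not yet measured. It differs from compound 3 by methyl in place of hydrogen on an aromatic carbon, the same kind of change as that from compound 1 to compound 2, but not the same: in compound 2 the methyl sits between two ring nitrogen atoms, next to the ring atom that bears a large group, whereas in compound 4 it sits next to the ring nitrogen, next to the ring atom that bears a group of 9 heavy atoms, two ring bonds from the ring nitrogen. Because the earlier methyl gave an at least 33-fold higher number from compound 1 to compound 2 (1.52 log units; beyond the scatter), a loss is expected for compound 4 as well, though its different place makes a smaller step plausible. For compound 4 the expected step is a 7.1-fold higher number from compound 3 to compound 4 (0.85 log units; beyond the scatter). Compound 4 is estimated at 10 mg/kg, with a range from 2 mg/kg to 60 mg/kg.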

Compound 4, dose for half-maximal effect: > 100 mg/kg
Compound 4 gave a limit, no number; the forecaster's own chance of this, stated with the estimate: 25%; at least 10-fold (1.00 log units) between middle value and limit.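

In this assay, methyl in place of hydrogen on a different aromatic carbon, now on the core of compound 3, again brings a large loss: an at least 71-fold higher number from compound 3 to compound 4 (1.85 log units; beyond the scatter). From the compounds shown here alone, the loss therefore carries over from one core to the other, but its size on either core stays unknown, and the two steps cannot be ranked: the same change on two cores in this assay, an at least 33-fold higher number (1.52 log units; beyond the scatter) from compound 1 to compound 2 and an at least 71-fold higher number (1.85 log units; beyond the scatter) from compound 3 to compound 4; the limit leaves it open whether they differ. Compound 4 gives a limit and not a number, as does compound 2: the limit of > 100 mg/kg in this assay, at which 2 of the 4 values shown sit.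

The compounds shown leave open whether ethyl or chlorine in place of this methyl would give a number within the range of the assay. They also leave open how a longer chain or an amine in place of the amide would behave on this core.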